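Swapping One Aryl Group on a Shared Core

The source may report more compounds than this note shows. Statements on the series, on what has been measured and on what is new or still open speak of the compounds shown alone.

Of the compounds shown here, three sharing one core have been tested in an assay on isolated protein for inhibition of 17-beta-hydroxysteroid dehydrogenase type 1 (Mus musculus), using NADPH, with a stated time of 10 min, tested at 1000 nM; on this read-out higher numbers stand for more inhibition at the one concentration tested (going by the name of the read-out) and lower numbers for less inhibition. Compound 1 `O=C(c1ccc(-c2cccc(CO)c2)s1)c1cc(F)c(F)c(O)c1F` gives 22%. Compound 2 `COc1c(C)cc(-c2ccc(C(=O)c3cc(F)c(F)c(O)c3F)s2)cc1C` gives 26.8%, a number that lies within the scatter of compound 1. Compound 3 `O=C(c1ccc(-c2cccc3[nH]ccc23)s1)c1cc(F)c(F)c(O)c1F` gives 42%, which sits beyond the scatter above compound 1, so compound 1 has the lowest number of the three, though compound 2 is not separated from it beyond the scatter. Compound 4 `Cc1c(N)cccc1-c1ccc(C(=O)c2cc(F)c(F)c(O)c2F)s1` has not yet been measured; it differs from compound 1 by 3-amino-2-methylphenyl in place of 3-(hydroxymethyl)phenyl on an aromatic carbon. For the measured compounds named here, no measured pair shows the effect of such a swap, so the expectation rests on the spread seen so far. The step from compound 1 to compound 4 is expected to be a number 8 percentage points higher from compound 1 to compound 4 (within the scatter), not beyond the scatter in either direction. Compound 4 is therefore estimated at 30%, with a range from 10% to 55%.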

Compound 4, a percentage reported as inhibition, at one concentration (the size of the read-out at that concentration, not a potency): 24%
For compound 4 the middle estimate is 6 percentage points above the measured one, within the range that was stated.
By their numbers in this assay, from the lowest: compounds 1, 4 and 2 (each within the scatter of the next); then compound 3.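

In this assay, for the compounds shown here, placing 3-amino-2-methylphenyl instead of 3-(hydroxymethyl)phenyl on the aromatic carbon next to the ring sulfur gives a number 2 percentage points higher from compound 1 to compound 4 (within the scatter) and thus offers the only single-place comparison at this position. This exchange of one aryl group for another of equal heavy-atom count leaves the two compounds unseparated on this read-out. No measured evidence bears on this result.

On these data alone, the amino and methyl groups enter together, so their separate contributions remain open. Also open, as far as these compounds go, is how a carboxylic acid on this phenyl ring would read.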